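Removing the nitro group: from compound 3 to compound 4

The source may report more compounds than this note shows. Statements on the series, on what has been measured and on what is new or still open speak of the compounds shown alone.

Measured so far in a functional assay (Trachealis) for inhibition, with Cavia porcellus as the target; on this read-out higher numbers stand for weaker inhibition and lower numbers for stronger inhibition:
- compound 1, `CC1(C)Oc2ccc(C#N)cc2[C@@H](n2cccc2)[C@@H]1O`; here compound 1 gives > 20000 nM, which is a limit of the assay and not a number.
- compound 2, `CCc1cccn1C1=CC(C)(C)Oc2ccc(C#N)cc21`; here compound 2 gives > 20000 nM, again a limit of the assay.
- compound 3, `CC1(C)C=C(n2cccc2[N+](=O)[O-])c2cc(C#N)ccc2O1`; here compound 3 gives 690 nM.

Within the data shown here, compound 3 holds the only numerical value in this assay; the other two results are limits. Among the measured compounds shown here, the single step that can be sized is an at least 28-fold lower number from compound 2 to compound 3 (1.46 log units; beyond the scatter), and it stands out against (the limit of > 20000 nM in this assay, at which 2 of the 3 values shown sit).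

Compound 4, `CC1(C)C=C(n2cccc2)c2cc(C#N)ccc2O1`, is not yet measured. It differs from compound 3 as follows: hydrogen in place of nitro on an aromatic carbon. For the measured compounds named here, the only measured step that bears on this change runs the other way in kind, exchanging ethyl for nitro rather than nitro for hydrogen, and it was large. Taking it as the nearest guide, the loss of the nitro group from compound 3 is expected to cost potency, so a step of an 8.7-fold higher number from compound 3 to compound 4 (0.94 log units; beyond the scatter) is expected, toward weaker inhibition. Compound 4 is therefore estimated at 6000 nM, with a plausible range from 1200 nM to 30000 nM, and a fair chance that this assay returns only a limit.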

Compound 4, half-maximal inhibitory concentration: 4080 nM
Beside the measured number, compound 4's estimate is 1.5-fold (0.17 log units) above it, and the stated range covers the measured number.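

In this assay the hydrogen compound gives this position its first reference point: the change shows a 5.9-fold higher number from compound 3 to compound 4 (0.77 log units; beyond the scatter) and so leaves a measurable value without the nitro group, although inhibition is weaker than with nitro. Seen from the ethyl side, the same compound gives an at least 4.9-fold lower number from compound 2 to compound 4 (0.69 log units; beyond the scatter) so hydrogen sits between ethyl and nitro, and the large step between those two now divides into a part lost with ethyl and a part gained with nitro. Compound 2 gives > 20000 nM which is a limit of the assay and not a number, so the ethyl part of that division is only a bound: the limit of > 20000 nM in this assay, at which 2 of the 4 values shown sit.

The three compounds place one small and two larger groups on the aromatic carbon next to the ring nitrogen, which is too few to say what orders them, and an amine, a carboxylic acid or a methyl group at that place could fall anywhere relative to them. Also open, as far as these compounds go, is whether nitro would give a similar step on the core of compound 1, which carries hydrogen at this place and stands at a limit.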